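The compounds below may be only part of what the source reports. "The series", "measured", "known", "first", "only" and "open" are said of these compounds alone.

Measured in a functional assay, read by fluorescence and spectrophotometry, with a stated time of 1 h; a higher number here means that more compound is needed for the effect, a lower number that less compound is needed:

- compound 1 `CCCCCCCCCCCCS(=O)(=O)/C=C/c1ccc(O)c(O)c1`: 8500 nM
- compound 2 `C=CCCCCCCS(=O)(=O)/C=C/c1ccc(O)c(O)c1`: 6400 nM
- compound 3 `O=S(=O)(/C=C/c1ccc(O)c(O)c1)CCCCCCCCO`: 6700 nM

These three numbers cannot be told apart. Compound 3, at 6700 nM, lies within the scatter of both other compounds, as a 1.0-fold higher number from compound 2 to compound 3 (0.02 log units; within the scatter) and a 1.3-fold lower number from compound 1 to compound 3 (0.10 log units; within the scatter) show. The remaining pair gives the same picture, with a 1.3-fold lower number from compound 1 to compound 2 (0.12 log units; within the scatter).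

The next compound is compound 4 `O=S(=O)(/C=C/c1ccc(O)c(O)c1)CCCCCCCO`, which has not yet been measured. It differs from compound 3 as follows: hydroxy in place of hydroxymethyl on a saturated chain carbon, seven bonds along the chain from a sulfonyl sulfur. In words, hydroxy stands in place of hydroxymethyl on a saturated chain carbon, seven bonds along the chain from a sulfonyl sulfur.

Among the measured compounds shown here, no measured step makes this exact change, so the evidence is indirect. The closest guides are the other steps that alter this chain while the core stays the same, namely a 1.3-fold lower number from compound 1 to compound 3 (0.10 log units; within the scatter) and a 1.0-fold higher number from compound 2 to compound 3 (0.02 log units; within the scatter). Neither moved the number beyond the scatter, and the change to compound 4 is a small one on the same chain. The expected result is therefore no shift beyond the scatter in this assay, with an estimated 1.0-fold higher number from compound 3 to compound 4 (0.02 log units; within the scatter). For compound 4 the expected value is 7000 nM, with an estimated range from 3800 nM to 13000 nM.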

Compound 4, half-maximal effective concentration: 5900 nM
Compound 4: middle estimate off by 1.2-fold (0.07 log units), on the high side, within the range that was stated.
By their numbers in this assay, from the lowest: compounds 4, 2, 3 and 1 (each within the scatter of the next).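

In this assay, among the compounds shown here, the step that takes hydroxymethyl to hydroxy, seven bonds along the chain from a sulfonyl sulfur, gives a 1.1-fold lower number from compound 3 to compound 4 (0.06 log units; within the scatter) and stays within the scatter; this is the first direct reading of a shortened chain that still carries hydroxy. The wider comparisons agree: hydroxymethyl in place of vinyl gives a 1.1-fold lower number from compound 2 to compound 4 (0.04 log units; within the scatter), and hydroxy in place of pentyl gives a 1.4-fold lower number from compound 1 to compound 4 (0.16 log units; within the scatter), so none of the changes among these four compounds moves the number beyond the scatter, and no order among them can be claimed. No measurement is available that would explain why this chain tolerates these changes.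

The compounds shown leave open whether an amine or a carboxylic acid in place of the hydroxy, or a much shorter chain, would move the number beyond the scatter in this assay. On these data alone, all four compounds also share the same core, so what a change to that core, such as a methoxy group in place of a hydroxy group, would do to the number remains unknown.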